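Replacing the benzimidazole of compound 1 with a pyrazine

The source may report more compounds than this note shows. Statements on the series, on what has been measured and on what is new or still open speak of the compounds shown alone.

Measured compounds:
- compound 1 `Cc1nc(C(F)(F)F)ccc1C(=O)Nc1ccc(Cl)c(-c2nc3ccccc3n2C)c1`: 9 nM
- compound 2 `Cc1nc(C(F)(F)F)ccc1C(=O)Nc1ccc(Cl)c(-c2nc3c(n2C)CCCC3)c1`: 150 nM
- compound 3 `Cc1nc(C(F)(F)F)ccc1C(=O)Nc1ccc(Cl)c(-n2cccn2)c1`: 450 nM

In an assay on C3H 10T1/2 cells for inhibition of Sonic hedgehog protein (Mus musculus), read by a luciferase reporter (on this read-out higher numbers stand for weaker inhibition and lower numbers for stronger inhibition), compound 1 gives the lowest number of the three, with compound 2 at 150 nM and compound 3 at 450 nM. Both steps away from compound 1 are large: a 17-fold higher number from compound 1 to compound 2 (1.22 log units; beyond the scatter) and a 50-fold higher number from compound 1 to compound 3 (1.70 log units; beyond the scatter). Between the two weaker compounds the gap is modest: a 3.0-fold higher number from compound 2 to compound 3 (0.48 log units; beyond the scatter).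

Compound 4 `Cc1nc(C(F)(F)F)ccc1C(=O)Nc1ccc(Cl)c(-c2cnccn2)c1` is not yet measured. It differs from compound 1 in one place: pyrazin-2-yl in place of 1-methyl-1H-benzimidazol-2-yl on an aromatic carbon. This change, like the step to compound 3, removes the 1-methyl-1H-benzimidazol-2-yl group and puts a smaller aromatic ring with two nitrogens in its place, ortho to the chloro group. Since the step to compound 3 weakened inhibition a great deal, and even the change to compound 2 did not hold the number of compound 1, a large rise is expected for compound 4, somewhat like a 50-fold higher number from compound 1 to compound 3 (1.70 log units; beyond the scatter). Compound 4 is therefore estimated at 300 nM, within 80 nM to 1200 nM, an expected step of a 33-fold higher number from compound 1 to compound 4 (1.52 log units; beyond the scatter) in this assay.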

Compound 4, half-maximal inhibitory concentration: 1700 nM
For compound 4 the middle estimate is 5.7-fold (0.75 log units) below the measured one, and the stated range ends below it.
By their numbers in this assay, from the lowest: compound 1; then compound 2; then compound 3; then compound 4.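

In this assay, pyrazin-2-yl gives the largest rise seen at this position (a 190-fold higher number from compound 1 to compound 4 (2.28 log units; beyond the scatter)), although the hydrogen-bond acceptor count is the same in it and in the 1-methyl-1H-benzimidazol-2-yl group it replaces, so that count alone does not set the number here. The five-membered 1H-pyrazol-1-yl also reads lower than the six-membered pyrazin-2-yl (a 3.8-fold higher number from compound 3 to compound 4 (0.58 log units; beyond the scatter)). The two-ring group of compound 2 keeps a clear lead over pyrazin-2-yl too (an 11-fold higher number from compound 2 to compound 4 (1.05 log units; beyond the scatter)), so among these four compounds, both two-ring groups give lower numbers than both single-ring groups.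

No measurement shown explains these steps. On these data alone, how pyridin-2-yl, with one ring nitrogen, or an open chain such as an amine would read on this aromatic carbon remains open.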